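This account rests on a few compounds, and the source may have more. Where it says the series, first, only, none or still open, it means among the compounds named here.

Measured in a functional assay on HeLa cells (Homo sapiens) for inhibition, read by sulforhodamine B assay; a lower number here means a stronger inhibitor, a higher number a weaker inhibitor:
- Compound 1 `O=C1C=C(NCc2ccccc2)C(=O)c2c1nc1n2[C@H]2OC[C@@H](O)[C@H]2OC1`: > 8000 nM, a limit
- Compound 2 `O=C1C(Nc2ccccc2)=CC(=O)c2c1nc1n2[C@H]2OC[C@@H](O)[C@H]2OC1`: > 8000 nM, a limit
- Compound 3 `O=C1C=C(NC2CCCCC2)C(=O)c2c1nc1n2[C@H]2OC[C@@H](O)[C@H]2OC1`: > 16000 nM, a limit

Compound 2 has no number, only the limit > 8000 nM. It shares that position with the rest of the set, which holds the limit of > 8000 nM in this assay, at which 2 of the 3 values shown sit, and (the limit of > 16000 nM in this assay, at which 1 of the 3 values shown sits).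

Compound 4 `O=C1C(Nc2ccc(C(F)(F)F)cc2)=CC(=O)c2c1nc1n2[C@H]2OC[C@@H](O)[C@H]2OC1` differs from compound 2 in one place, with trifluoromethyl in place of hydrogen on an aromatic carbon, so that phenyl becomes 4-(trifluoromethyl)phenyl: trifluoromethyl in place of hydrogen on an aromatic carbon.

For the measured compounds named here, only one measured step is available, a step that the two limits leave unreadable from compound 1 to compound 3. It concerns cyclohexyl in place of benzyl on an amine nitrogen, which is a different change, and its size cannot be read. Going by the values given here, no measured step therefore gives a size for this change, so no step beyond the scatter is expected in this assay, in either direction. The expected change is a step that the limit leaves unreadable from compound 2 to compound 4, an estimate set against a limit. Compound 4 is expected to report only a limit, and its estimated value is 10000 nM, with an estimated range from 3000 nM to 30000 nM.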

Compound 4, half-maximal inhibitory concentration: 8920 nM
Compound 4: middle estimate off by 1.1-fold (0.05 log units), on the high side; the range from low to high includes it.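

For the compounds shown here, compound 2 is known only as a limit, so the step from it to compound 4 cannot be read, and this result yields no new step. The compounds shown leave open whether trifluoromethyl in place of hydrogen on an aromatic carbon changes anything in this assay.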